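The source may hold more compounds than are shown below. What is called first, only, known or untested is meant among the compounds shown, and "the series" means these compounds.

Compound 1 `Cc1c(-c2csc(/N=C3\S/C(=C\c4ccc(Cl)cc4)C(=O)N3c3ccccc3)n2)c(=O)n(-c2ccccc2)n1C` — in a functional assay on A549 cells (Homo sapiens) for cytotoxicity, read by sulforhodamine B assay, with a stated time of 72 h (on this read-out higher numbers stand for weaker inhibition and lower numbers for stronger inhibition), compound 1 gives > 100000 nM, which is a limit of the assay.
Compound 2 `Cc1ccc(/C=C2\S/C(=N\c3nc(-c4c(C)n(C)n(-c5ccccc5)c4=O)cs3)N(c3ccccc3)C2=O)cc1` — in this assay compound 2 gives > 100000 nM, likewise a limit of the assay.

Compound 2 thus stands only at a limit, with no number. The step that the two limits leave unreadable from compound 1 to compound 2 cannot be read because both values sit at the limit of > 100000 nM in this assay, at which 2 of the 2 values shown sit. Compound 3 `Cc1c(-c2csc(/N=C3\S/C(=C\c4ccco4)C(=O)N3c3ccccc3)n2)c(=O)n(-c2ccccc2)n1C` differs from compound 2 by furan-2-yl in place of 4-methylphenyl on a double-bonded chain carbon bound to a double-bonded ring carbon. Within the data shown here, no measured step bears on this change, and the one step measured is unreadable. For compound 3 the estimate is 100000 nM (range 20000 nM to 300000 nM). The expected step of a number no higher from compound 2 to compound 3 (the limit leaves the size open) is therefore an expectation that compound 3 most likely again reaches only the limit.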

Compound 3, half-maximal inhibitory concentration: 13700 nM
Beside the measured number, compound 3's estimate is 7.3-fold (0.86 log units) above it; the whole stated range lies above it.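

Among these compounds, at the double-bonded chain carbon bound to a double-bonded ring carbon, furan-2-yl gives the first number that is not a limit in this assay, with an at least 7.2-fold lower number from compound 2 to compound 3 (0.86 log units; beyond the scatter) and an at least 7.2-fold lower number from compound 1 to compound 3 (0.86 log units; beyond the scatter). The position can therefore move this read-out, which the 4-chlorophenyl and 4-methylphenyl pair could not show. Both steps remain minimum sizes, with the true sizes unreadable: the limit of > 100000 nM in this assay, at which 2 of the 3 values shown sit.

On these data alone, whether the step belongs to the oxygen of furan-2-yl or to the five-membered aromatic ring remains open. Also open, as far as these compounds go, is how thiophen-2-yl or pyridin-3-yl would read at this carbon.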